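This account rests on a few compounds, and the source may have more. Where it says the series, first, only, none or still open, it means among the compounds named here.

Measured so far in a functional assay on Bel-7402 cells (Homo sapiens) for cytotoxicity, read by resazurin assay, with a stated time of 72 h; on this read-out lower numbers stand for stronger inhibition and higher numbers for weaker inhibition:

Compound 1 `N#CCCSC(=S)NCc1nnc(-c2ccccc2)s1` — 18700 nM
Compound 2 `O=S(=O)(O)CCCSC(=S)NCc1cccnc1` — 6590 nM
Compound 3 `Fc1ccccc1-c1nnc(CCSC(=S)NCc2cccnc2)o1` — 5540 nM

Compound 3 gives the lowest number of the three. The gap to compound 2 lies within the usual scatter, so the two cannot be ordered against each other on this read-out; the gap to compound 1 lies beyond the scatter, so compound 3 does read as the more potent of that pair. The three compounds differ from one another in more than one place, so no single structural step can be read off between any two of them.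

Compound 4 `S=C(NCc1cccnc1)SCCc1nnc(-c2cccnc2)o1` has not yet been measured. It differs from compound 3 in one place: pyridin-3-yl in place of 2-fluorophenyl on an aromatic carbon. The 2-fluorophenyl group leaves and a pyridin-3-yl group enters on an aromatic carbon of the five-membered ring. Within the data shown here, no measured pair in the set isolates a change of this kind, so there is no step to lean on. The working expectation is that the step of a 1.1-fold higher number from compound 3 to compound 4 (0.03 log units; within the scatter) stays within the scatter, in no particular direction. Compound 4 is accordingly estimated at 6000 nM in this assay, with a range from 2500 nM to 15000 nM.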

Compound 4, half-maximal inhibitory concentration: 1370 nM
Estimate against measurement, compound 4: 4.4-fold (0.64 log units) above; measured number outside the range, below it.
By their numbers in this assay, from the lowest: compound 4; then compounds 3 and 2 (each within the scatter of the next); then compound 1.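

In this assay, the group on the aromatic carbon of the five-membered ring, next to the ring oxygen, can shift the read-out: pyridin-3-yl in place of 2-fluorophenyl gives a 4.0-fold lower number from compound 3 to compound 4 (0.61 log units; beyond the scatter). Among these compounds, this is the first single-place step, and it swaps a ring of carbon only bearing fluorine, with no hydrogen-bond acceptor, for a ring with one hetero atom and one hydrogen-bond acceptor. Nothing measured here bears on the cause of this step.

The compounds shown leave open whether the lower number follows the entering ring nitrogen or the departing fluorine, a question that a plain phenyl group on the same carbon would address. Also open, as far as these compounds go, is how pyridin-2-yl or pyridin-4-yl would read at this position.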